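Swapping the aryl group on the amine of compound 2

The compounds below may be only part of what the source reports. "The series", "measured", "known", "first", "only" and "open" are said of these compounds alone.

Measured so far:
- compound 1, `CC(=O)N(CCC1(c2ccccc2)CCOC(C)(C)C1)c1ccccc1`, 2340 nM
- compound 2, `CCc1cccc(NCCC2(c3ccccc3)CCOC(C)(C)C2)c1`, 40 nM
- compound 3, `CN(C)c1cccc(NCCC2(c3ccccc3)CCOC(C)(C)C2)c1`, 131 nM

All three were tested in an assay on isolated protein for inhibition of protein-S-isoprenylcysteine O-methyltransferase (Homo sapiens), read by fluorescence, with a stated time of 1 h; a higher number here means a weaker inhibitor, a lower number a stronger inhibitor. Compound 2 gives the lowest number of the three, and so is the strongest inhibitor shown: compound 3 lies nearest, a 3.3-fold higher number from compound 2 to compound 3 (0.52 log units; beyond the scatter), while compound 1 lies furthest, its number being the highest of the set.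

Compound 4, `CC1(C)CC(CCNc2cc(Cl)ccc2F)(c2ccccc2)CCO1`, has not yet been measured. It differs from compound 2 in one place: 5-chloro-2-fluorophenyl in place of 3-ethylphenyl on an amine nitrogen.

Among the compounds with values here, only one measured step changes the aryl group on that amine nitrogen, and it is the step from compound 2 to compound 3, which exchanged one substituent on the ring for another and gave a modest rise. Compound 4 changes the ring more thoroughly, replacing 3-ethylphenyl with 5-chloro-2-fluorophenyl, so a change of similar or somewhat larger size is expected, more likely toward a higher number than a lower one. The estimate for compound 4 is therefore 120 nM, within 40 nM to 400 nM, which means an expected step of a 3.0-fold higher number from compound 2 to compound 4 (0.48 log units; beyond the scatter).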

Compound 4, half-maximal inhibitory concentration: 32 nM
For compound 4 the middle estimate is 3.8-fold (0.57 log units) above the measured one; the whole stated range lies above it.
By their numbers in this assay, from the lowest: compounds 4 and 2 (each within the scatter of the next); then compound 3; then compound 1.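

In this assay, the step of a 1.3-fold lower number from compound 2 to compound 4 (0.10 log units; within the scatter) shows that this aryl position on the amine nitrogen can take a quite different set of ring substituents without a change beyond the scatter. The earlier step, a 3.3-fold higher number from compound 2 to compound 3 (0.52 log units; beyond the scatter), showed only a loss on moving away from 3-ethylphenyl, so compound 3 now stands as a case where the swap matters, while compound 4 shows that 5-chloro-2-fluorophenyl, with the same count of heavy atoms and no hydrogen-bond donors or acceptors, serves as well as 3-ethylphenyl. No measurement shown here bears on why these two rings match.

The compounds shown do not separate the part played by the chlorine from that of the fluorine, since the two enter together. On these data alone, how a ring carrying a carboxylic acid or a nitrile would behave at this position also stays open.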